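From trifluoromethyl to nitro: one group changed

A few compounds are considered here, and "the series" means these few. Any claim that something is new, unique, unknown or untested is made for them only; others in the source may bear on it.

Measured so far:
Compound 2 `FC(F)(F)c1ccc(-c2cn(Cc3ccccc3)c3c2CNCC3)cc1`: 167 nM
Compound 1 `FC(F)(F)Oc1ccc(-c2cn(Cc3ccccc3)c3c2CNCC3)cc1`: 10000 nM

Among the measured compounds shown here, in an assay on HEK293 cells for displacement of a labelled ligand from 5-hydroxytryptamine receptor 7 (Rattus norvegicus), with a stated time of 60 min (on this read-out lower numbers stand for stronger inhibition and higher numbers for weaker inhibition), compound 2 gives the lower of the two numbers; the only measured step, a 60-fold lower number from compound 1 to compound 2 (1.78 log units; beyond the scatter), came from changing the group at the same place. Compound 3 `O=[N+]([O-])c1ccc(-c2cn(Cc3ccccc3)c3c2CNCC3)cc1` differs from compound 2 by nitro in place of trifluoromethyl on an aromatic carbon. That step shows this place can shift the number strongly, but it says nothing about nitro, so the direction is open. A moderate, uncertain change is expected: a 2.4-fold higher number from compound 2 to compound 3 (0.38 log units; beyond the scatter). Compound 3 is therefore estimated at 400 nM, with a wide range from 60 nM to 3000 nM.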

Compound 3, inhibition constant: 450 nM
For compound 3 the middle estimate is 1.1-fold (0.05 log units) below the measured one; the measured number falls inside the stated range.
By their numbers in this assay, from the lowest: compound 2; then compound 3; then compound 1.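

Nitro gives a second comparison at this place, on an aromatic carbon para to a large group: there is a 2.7-fold higher number from compound 2 to compound 3 (0.43 log units; beyond the scatter) as a modest step, so trifluoromethyl keeps the lowest number of the three. Against that stands a 22-fold lower number from compound 1 to compound 3 (1.35 log units; beyond the scatter) as a large step, which sets trifluoromethoxy apart from the other two groups.

On these data alone, whether an amine or a carboxylic acid at this place would give a lower or a higher number stays open. Nothing measured here explains why these three groups differ.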